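The compounds below may be only part of what the source reports. "The series", "measured", "known", "first", "only" and "open" are said of these compounds alone.

Three compounds share one core and differ only in the amine at the end of a side chain. Compound 1 `CN(CC1CC1)CC1(O)CCN(CCCc2c[nH]c3ccc(-n4cnnc4)cc23)CC1` gives 1.1 nM in a functional assay on CHO cells for agonist activity at 5-hydroxytryptamine receptor 1D (Homo sapiens), read by GTPgammaS binding; on this read-out lower numbers stand for an effect already at smaller amounts and higher numbers for an effect only at larger amounts of compound. Compound 2 `CN(CC(C)(C)C)CC1(O)CCN(CCCc2c[nH]c3ccc(-n4cnnc4)cc23)CC1` gives 1.6 nM, and compound 3 `CC1(C)CCCN(CC2(O)CCN(CCCc3c[nH]c4ccc(-n5cnnc5)cc34)CC2)C1` gives 0.9 nM, the lowest of the three numbers, although the steps of a 1.2-fold lower number from compound 1 to compound 3 (0.09 log units; within the scatter) and a 1.8-fold lower number from compound 2 to compound 3 (0.25 log units; within the scatter) both stay within the scatter, as does a 1.5-fold higher number from compound 1 to compound 2 (0.16 log units; within the scatter). Compound 4 `Cc1ccccc1CN(C)CC1(O)CCN(CCCc2c[nH]c3ccc(-n4cnnc4)cc23)CC1` has not been measured yet. It carries methyl(2-methylbenzyl)amino in place of 3,3-dimethylpiperidin-1-yl on a saturated chain carbon bound to a saturated ring carbon. Since every earlier exchange of this amine left the number nearly unchanged, the step of a 1.7-fold higher number from compound 3 to compound 4 (0.22 log units; within the scatter) is expected to lie within the scatter as well. Compound 4 is therefore estimated at 1.5 nM, with a range from 0.5 nM to 4.5 nM.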

Compound 4, concentration for half-maximal effect: 3.7 nM
For compound 4 the middle estimate is 2.5-fold (0.39 log units) below the measured one; measured number inside the range.
By their numbers in this assay, from the lowest: compounds 3, 1 and 2 (each within the scatter of the next); then compound 4.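

In this assay, within the data shown here, this position, a saturated chain carbon bound to a saturated ring carbon, does not treat every amine alike: methyl(2-methylbenzyl)amino brings the first steps beyond the scatter, with a 4.1-fold higher number from compound 3 to compound 4 (0.61 log units; beyond the scatter) and a 3.4-fold higher number from compound 1 to compound 4 (0.53 log units; beyond the scatter) and also a 2.3-fold higher number from compound 2 to compound 4 (0.36 log units; beyond the scatter). All three steps are modest, so the position responds to this exchange, but not strongly. No measurement at hand explains the shift.

From the compounds shown here alone, whether the shift goes with the aromatic ring or with its methyl group remains open. A plain benzyl group on the amine would separate the two.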